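From methylsulfanyl to 2,2,2-trifluoroethoxy on the shared core

This account rests on a few compounds, and the source may have more. Where it says the series, first, only, none or still open, it means among the compounds named here.

Measured in a functional assay on HeLa cells (Homo sapiens) for antiproliferative activity, read by CCK-8 assay, with a stated time of 72 h; on this read-out higher numbers stand for weaker inhibition and lower numbers for stronger inhibition:
Compound 1 `COc1ccc(-c2cncnc2-c2cc(OC)c(OC)c(OC)c2)cc1F` gives 500 nM
Compound 2 `COc1ccc(-c2cncnc2-c2cc(OC)c(OC)c(OC)c2)cc1Cl` gives 320 nM
Compound 3 `COc1cc(-c2ncncc2-c2ccc(SC)cc2)cc(OC)c1OC` gives 220 nM

Compound 3 stands level with compound 2 within the scatter (a 1.5-fold lower number from compound 2 to compound 3 (0.16 log units; within the scatter)) but apart from compound 1 (a 2.3-fold lower number from compound 1 to compound 3 (0.36 log units; beyond the scatter)). Compound 4 `COc1cc(-c2ncncc2-c2ccc(OCC(F)(F)F)cc2)cc(OC)c1OC` keeps the shared core and carries 2,2,2-trifluoroethoxy in place of methylsulfanyl on an aromatic carbon, para to a large group (2,2,2-trifluoroethoxy in place of methylsulfanyl on an aromatic carbon).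

For the measured compounds named here, no measured step exchanges this group alone. The nearest evidence is the exchange of the whole aromatic group that carries it, and those steps are small. Compound 1, which lacks methylsulfanyl, differs only modestly (a 2.3-fold lower number from compound 1 to compound 3 (0.36 log units; beyond the scatter)). From the compounds shown here alone, a modest move toward a higher number in this assay is therefore expected, though the new group is untested here and the direction is uncertain. The expected step is a 2.0-fold higher number from compound 3 to compound 4 (0.31 log units; beyond the scatter). For compound 4 the estimated value is 450 nM, with an expected range from 130 nM to 1500 nM.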

Compound 4, half-maximal inhibitory concentration: 10200 nM
For compound 4 the middle estimate is 23-fold (1.36 log units) below the measured one; the whole stated range lies below it.
By their numbers in this assay, from the lowest: compounds 3, 2 and 1 (each within the scatter of the next, the first and the last beyond it); then compound 4.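

In this assay the step of a 46-fold higher number from compound 3 to compound 4 (1.67 log units; beyond the scatter) is large, and it shows that this place, on an aromatic carbon para to a large group, is far from indifferent to what it carries. The earlier exchanges on the shared core stayed small, the widest being a 2.3-fold lower number from compound 1 to compound 3 (0.36 log units; beyond the scatter), so they gave no sign that one substituent change here could cost so much activity. No measurement shown here bears on why 2,2,2-trifluoroethoxy is so much weaker than methylsulfanyl at this place.

The compounds shown leave open whether the loss follows from the oxygen that takes the place of sulfur or from the three fluorine atoms at the end of the chain. Ethoxy and 2,2,2-trifluoroethylsulfanyl at the same place would separate the two.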